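The source may hold more compounds than are shown below. What is called first, only, known or untested is meant among the compounds shown, and "the series" means these compounds.

Within the data shown here, compound 2 `C=CCn1c(=O)/c(=C\c2cccc(Cl)c2Cl)[nH]c(=O)/c1=C\c1ccccc1OC` is the one member of this small set for which a single number has been reported: in a functional assay on HL-60 cells (Homo sapiens) for cytotoxicity, read by CCK-8 assay, with a stated time of 72 h (on this read-out lower numbers stand for stronger inhibition and higher numbers for weaker inhibition), compound 2 gives 2000 nM. Compound 1 `COc1ccccc1/C=c1/[nH]c(=O)/c(=C\c2cccc(Cl)c2Cl)[nH]c1=O`, which has no allyl group, is recorded in this assay as "not active" (no number reported). Compound 3 `C=CCn1c(=O)/c(=C\c2cccc(Br)c2)[nH]c(=O)/c1=C\c1cccc(Br)c1`, which carries two 3-bromophenyl groups, is likewise recorded in this assay as "not active" (no number reported). Among the measured compounds shown here, compound 2 therefore stands as the only compound with a measured potency, while the two others show no number at all. Compound 4 `C=CCn1c(=O)/c(=C\c2cccc(C)c2)[nH]c(=O)/c1=C\c1ccccc1OC` differs from compound 2 in one place: 3-methylphenyl in place of 2,3-dichlorophenyl on a double-bonded chain carbon bound to an aromatic carbon. For the measured compounds named here, no measured pair differing only in this way is available, so the size of the step cannot be read from the data. Compound 1 and compound 3 both lack the 2,3-dichlorophenyl group and both are without a number, which points towards a step to weaker inhibition beyond the usual scatter, though a result within the scatter cannot be excluded. Compound 4 is expected to give 6000 nM in this assay, within a range of 1500 nM to 30000 nM. That corresponds to an estimated step of a 3.0-fold higher number from compound 2 to compound 4 (0.48 log units; beyond the scatter).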

Compound 4, half-maximal inhibitory concentration: 16700 nM
For compound 4 the middle estimate is 2.8-fold (0.44 log units) below the measured one; low and high end bracket the measured number.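

In this assay, among these compounds, 3-methylphenyl in place of 2,3-dichlorophenyl on a double-bonded chain carbon bound to an aromatic carbon gives an 8.4-fold higher number from compound 2 to compound 4 (0.92 log units; beyond the scatter) and so provides the first measured step at this position. The exchange weakens inhibition, yet compound 4 still has a numerical value and is not recorded as "not active", so in this pair the 2,3-dichlorophenyl group is not required for a measurable result. Nothing available accounts for the size of this step.

The compounds shown leave open whether the difference follows the two chlorine atoms or the methyl group, since a single 3-chlorophenyl or a 2,3-dimethylphenyl group does not appear among them. They also do not show whether the step would keep its size if the 2-methoxyphenyl group on the other side of the core were replaced by an unsubstituted phenyl group.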